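Series notes: loss of the methylsulfanyl group from compound 2

The source may report more compounds than this note shows. Statements on the series, on what has been measured and on what is new or still open speak of the compounds shown alone.

Compound 1 `CCCCC[Se]c1nc(NCc2ccc(SC)cc2)c2ccccc2n1` gives 65000 nM in a functional assay on MCF7 cells (Homo sapiens) for cytotoxicity, read by MTT assay, with a stated time of 72 h; on this read-out higher numbers stand for weaker inhibition of growth and lower numbers for stronger inhibition of growth.
Compound 3 `CCCCCSc1nc(NCc2ccc([Se]C)cc2)c2ccccc2n1` gives 75200 nM in this assay.
Compound 2 `CSc1ccc(CNc2nc([SeH])nc3ccccc23)cc1` reaches only > 100000 nM in this assay.

Among the compounds with values here, the value of compound 2 is a limit of this assay and not a number; it is the one value of the three that sits at the limit of > 100000 nM in this assay, at which 1 of the 3 values shown sits. Compound 1 and compound 3 show numbers within the usual scatter of each other, so no order between them is claimed. Within the data shown here, the single step between measured compounds that differ in one place, an at least 1.5-fold higher number from compound 1 to compound 2 (0.18 log units; that floor lies within the scatter), runs into that limit and concerns the selenium, not the aromatic ring.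

Compound 4 `[SeH]c1nc(NCc2ccccc2)c2ccccc2n1` is not yet measured. It differs from compound 2 by hydrogen in place of methylsulfanyl on an aromatic carbon. Among the measured compounds shown here, no measured step touches this part of the structure, so nothing recorded bears directly on the change; the step of an at least 1.5-fold higher number from compound 1 to compound 2 (0.18 log units; that floor lies within the scatter) is the only one available and it lies elsewhere. With compound 2 standing at the limit, compound 4 is expected to remain there or close to it. The estimate for compound 4 in this assay is 120000 nM, with a range from 60000 nM to 250000 nM. The expected step is a step that the limit leaves unreadable from compound 2 to compound 4, with no direction beyond the scatter.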

Compound 4, concentration for total growth inhibition: > 100000 nM
Compound 4: a limit, no number; the forecaster's own chance of this, stated with the estimate: 70%; the middle value does not contradict the limit.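

Compound 4 gives > 100000 nM in this assay, a limit and not a number. Compound 2 stands at the same limit, so no step can be read between compound 2 and compound 4: the limit of > 100000 nM in this assay, at which 2 of the 4 values shown sit. The compounds shown leave open what hydrogen in place of methylsulfanyl on an aromatic carbon does in a compound with a measurable number, such as compound 1.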